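Swapping the Halophenyl on the Triazole Benzyl Arm

The source may report more compounds than this note shows. Statements on the series, on what has been measured and on what is new or still open speak of the compounds shown alone.

Among the measured compounds shown here, compound 2 `O=c1ccoc2cc(OCc3cn(Cc4ccc(Br)cc4)nn3)ccc12` is one of two compounds measured in a functional assay on A549 cells (Homo sapiens) for cytotoxicity, read by MTT assay, with a stated time of 48 h; a higher number here means a weaker inhibitor, a lower number a stronger inhibitor. In this assay compound 2 gives only a limit, > 100000 nM. Compound 1 `O=c1ccoc2cc(OCc3cn(Cc4cccc(Cl)c4)nn3)ccc12` gives 13700 nM in this assay, and the step of an at least 7.2-fold higher number from compound 1 to compound 2 (0.86 log units; beyond the scatter) runs toward (the limit of > 100000 nM in this assay, at which 1 of the 2 values shown sits). Compound 3 `O=c1ccoc2cc(OCc3cn(Cc4ccccc4F)nn3)ccc12` differs from compound 2 by 2-fluorophenyl in place of 4-bromophenyl on a saturated chain carbon bound to an aromatic nitrogen. For the measured compounds named here, only the step of an at least 7.2-fold higher number from compound 1 to compound 2 (0.86 log units; beyond the scatter) bears on this change, and it too was a halophenyl swap, so a shift of similar size, most plausibly back toward compound 1, is expected. Compound 3 is estimated at 30000 nM in this assay, between 8000 nM and 100000 nM. That expectation means an at least 3.3-fold lower number from compound 2 to compound 3 (0.52 log units; beyond the scatter).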

Compound 3, half-maximal inhibitory concentration: 10800 nM
For compound 3 the middle estimate is 2.8-fold (0.44 log units) above the measured one; low and high end bracket the measured number.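

In this assay the change from 3-chlorophenyl to 2-fluorophenyl is a 1.3-fold lower number from compound 1 to compound 3 (0.10 log units; within the scatter) and separates the two arms not at all, whereas 4-bromophenyl alone stands apart, with an at least 9.2-fold lower number from compound 2 to compound 3 (0.96 log units; beyond the scatter) as its step. So on this saturated chain carbon, the halophenyl swap does not shift the value each time; among the three compounds, only compound 2 departs. Compound 2 carries a limit of the assay, so its step has an open end: (the limit of > 100000 nM in this assay, at which 1 of the 3 values shown sits).

The compounds shown leave open whether compound 2 stands apart for its bromine or for where that atom sits. A 4-chlorophenyl or a 3-bromophenyl arm would separate the two.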